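A few compounds are considered here, and "the series" means these few. Any claim that something is new, unique, unknown or untested is made for them only; others in the source may bear on it.

Measured compounds, with their read-outs in a functional assay on the whole organism (strain Swiss) with Mus musculus as the target, in the maximal electroshock model, with a stated time of 1 h, at a dose of 100 mg/kg by the intraperitoneal route; a higher number here means a stronger effect of the compound at the dose given, a lower number a weaker effect:

- compound 1 `COc1cccc(N2CCN(C(=O)C(C)N3C(=O)CCC3=O)CC2)c1`: 0%
- compound 2 `CC(C(=O)N1CCN(c2ccccc2)CC1)N1C(=O)CCC1=O`: 0%
- compound 3 `CCC(C(=O)N1CCN(c2cccc(F)c2)CC1)N1C(=O)CCC1=O`: 0%

Compound 3 stands level with compounds 1 and 2 at the digits given. Its nearest neighbour on the numbers is compound 1, with no change within the scatter; its furthest is compound 2, again with no change within the scatter. Within the data shown here, the only single-point step measured, no change at the digits printed from compound 1 to compound 2 (within the scatter), concerns hydrogen in place of methoxy on an aromatic carbon and shows a flat read-out.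

Compound 4 `CC(C(=O)N1CCN(c2cccc(F)c2)CC1)N1C(=O)CCC1=O` has not yet been measured in this assay. It differs from compound 3 as follows: hydrogen in place of methyl on a saturated chain carbon, two bonds along the chain from an amide-type nitrogen in a ring and a carbonyl carbon. Among the measured compounds shown here, no measured step touches this chain position, so there is no direct precedent for the change; the one step recorded elsewhere in the molecule leaves the read-out unmoved, and all three measured compounds sit at the same level.

On that basis compound 4 is expected to give 0% in this assay, with a range of 0% to 10%. The expected step is no change at the digits printed from compound 3 to compound 4 (within the scatter), that is, no change beyond the scatter.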

Compound 4, a percentage reported as activity, at one dose (the size of the read-out at that dose, not a potency): 0%
The estimate for compound 4 equals the measured number at the digits printed, and the stated range covers the measured number.
By their numbers in this assay, from the lowest: compounds 1, 2, 3 and 4 (each within the scatter of the next).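

In this assay, among these compounds, the change from ethyl to methyl on the saturated chain carbon, two bonds along the chain from an amide-type nitrogen in a ring and a carbonyl carbon, gives no change at the digits printed from compound 3 to compound 4 (within the scatter) and is the first measured change at this chain position. The aromatic carbon also gains two further exchanges: fluoro in place of hydrogen gives no change at the digits printed from compound 2 to compound 4 (within the scatter) and fluoro in place of methoxy gives no change at the digits printed from compound 1 to compound 4 (within the scatter) in the same read-out, so neither site separates these compounds. No supporting information bears on this flat result.

With compound 4 at 0% and the other three compounds at the same printed level, these steps cannot show whether either site influences the read-out, since a substituent that reduced the effect could not be told apart from one that changed nothing. On these data alone, whether a longer chain such as propyl on the saturated chain carbon, or an amine or a carboxylic acid on an aromatic carbon, would raise the read-out remains open.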